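Swapping the aryl group on the triazole of compound 3

The compounds below may be only part of what the source reports. "The series", "measured", "known", "first", "only" and "open" are said of these compounds alone.

Measured compounds:
compound 1, `COc1cc2c(Oc3ccc(NC(=O)c4nnn(-c5ccc(F)c(F)c5)c4C(F)(F)F)cc3F)ccnc2cc1OCCCN1CCCCC1`, 180 nM
compound 2, `COc1cc2c(Oc3ccc(NC(=O)c4nnn(-c5ccc(F)c(F)c5)c4C(F)(F)F)cc3F)ccnc2cc1OCCCN1CCC(C)CC1`, 190 nM
compound 3, `COc1cc2c(Oc3ccc(NC(=O)c4nnn(-c5ccccc5Cl)c4C(F)(F)F)cc3F)ccnc2cc1OCCCN1CCN(C)CC1`, 270 nM

All three compounds share one core and were tested in a functional assay on HT-29 cells (Homo sapiens) for cytotoxicity, read by MTT assay, with a stated time of 72 h; on this read-out higher numbers stand for weaker inhibition and lower numbers for stronger inhibition. Compound 3 gives the highest of the three numbers, yet its gaps to compound 2 and to compound 1 both lie within the scatter of repeated measurement, so the three values cannot be told apart with confidence.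

Among the compounds with values here, the only measured step between neighbours is a 1.1-fold higher number from compound 1 to compound 2 (0.02 log units; within the scatter), a change on a saturated ring carbon, and it shows no effect beyond the scatter.

Compound 4, `COc1cc2c(Oc3ccc(NC(=O)c4nnn(-c5ccc(F)c(F)c5)c4C(F)(F)F)cc3F)ccnc2cc1OCCCN1CCN(C)CC1`, is not yet measured. Its difference from compound 3 is 3,4-difluorophenyl in place of 2-chlorophenyl on an aromatic nitrogen. Within the data shown here, no measured step addresses this change, since compound 1 and compound 2 differ from compound 4 at the amine end rather than at the aryl group. What can be said is that compound 1 and compound 2, which carry the same 3,4-difluorophenyl as compound 4, and compound 3, which carries the same amine as compound 4, all sit in one narrow band.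

Compound 4 is therefore expected to stay in that band, with an estimated step of a 1.3-fold lower number from compound 3 to compound 4 (0.11 log units; within the scatter). The estimate for compound 4 in this assay is 210 nM, with a range from 100 nM to 450 nM.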

Compound 4, half-maximal inhibitory concentration: 150 nM
Compound 4: middle estimate off by 1.4-fold (0.15 log units), on the high side, and the stated range covers the measured number.
By their numbers in this assay, from the lowest: compounds 4, 1, 2 and 3 (each within the scatter of the next).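

In this assay, within the data shown here, the step from 2-chlorophenyl to 3,4-difluorophenyl on the aromatic nitrogen of the five-membered ring gives the first direct look at this position: a 1.8-fold lower number from compound 3 to compound 4 (0.26 log units; within the scatter) shows that, for this pair, exchanging one halogen-bearing phenyl for another leaves no change that can be told from the scatter. Among these compounds, the same compound also gives the first direct comparisons at the amine end, where 4-methylpiperazin-1-yl in place of 4-methylpiperidin-1-yl gives a 1.3-fold lower number from compound 2 to compound 4 (0.10 log units; within the scatter) and 4-methylpiperazin-1-yl in place of piperidin-1-yl gives a 1.2-fold lower number from compound 1 to compound 4 (0.08 log units; within the scatter) and so these three ring amines cannot be told apart in this assay when the 3,4-difluorophenyl is present. No measurement of any property of these groups accompanies the numbers, so they describe the size of the steps and offer no explanation for them.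

Still open, as far as these compounds go, is whether a plain phenyl without halogen, a 4-methoxyphenyl or a small methyl on that nitrogen would also stay within the scatter. At the far end of the chain, a morpholine or a dimethylamino group remains an open question, as does whether the aryl swap gives the same result alongside piperidin-1-yl.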